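A few compounds are considered here, and "the series" means these few. Any claim that something is new, unique, unknown or untested is made for them only; others in the source may bear on it.

Three measured compounds share one core and differ only in the group on the aromatic carbon. Compound 1 `CC(C(=O)NCc1ccc(C(F)(F)F)cc1N1CCCCCC1)c1ccc(NS(C)(=O)=O)c(F)c1` gives 1.6 nM in an assay on CHO cells for antagonist activity at transient receptor potential cation channel subfamily V member 1 (Homo sapiens), read by FLIPR; on this read-out higher numbers stand for weaker inhibition and lower numbers for stronger inhibition. Compound 2 `CCCOc1cc(C(F)(F)F)ccc1CNC(=O)C(C)c1ccc(NS(C)(=O)=O)c(F)c1` gives 2 nM in this assay, and the step of a 1.3-fold higher number from compound 1 to compound 2 (0.10 log units; within the scatter). Compound 3 `CC(C(=O)NCc1ccc(C(F)(F)F)cc1OC1CCCCC1)c1ccc(NS(C)(=O)=O)c(F)c1` gives 0.7 nM in this assay; it holds the lowest of the three numbers, with a 2.3-fold lower number from compound 1 to compound 3 (0.36 log units; beyond the scatter) and a 2.9-fold lower number from compound 2 to compound 3 (0.46 log units; beyond the scatter).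

Compound 4 `CC(C(=O)NCc1ccc(C(F)(F)F)cc1SCc1ccccc1)c1ccc(NS(C)(=O)=O)c(F)c1` has not yet been measured. Compared with compound 3, the change is benzylsulfanyl in place of cyclohexyloxy on an aromatic carbon. The two steps that bear on this position, from compound 1 and from compound 2 to compound 3, were both modest, and the step from compound 1 to compound 2 lay within the scatter, so the group at this carbon has so far moved the number only a little. Compound 4 is therefore expected to stay close to compound 3, with an expected step of a 2.1-fold higher number from compound 3 to compound 4 (0.33 log units; beyond the scatter). In this assay compound 4 is estimated at 1.5 nM, with a range from 0.5 nM to 5 nM.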

Compound 4, inhibition constant: 0.5 nM
Compound 4: the middle estimate sits 3.0-fold (0.48 log units) above what was measured; low and high end bracket the measured number.
By their numbers in this assay, from the lowest: compounds 4 and 3 (each within the scatter of the next); then compounds 1 and 2 (each within the scatter of the next).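

In this assay, the aromatic carbon takes benzylsulfanyl, with its sulfur and its aromatic ring, as readily as cyclohexyloxy, with its oxygen and its non-aromatic ring: the result is a 1.4-fold lower number from compound 3 to compound 4 (0.15 log units; within the scatter), so these two different groups cannot be told apart. Compound 4 also clears the scatter against the other two compounds, with a 4.0-fold lower number from compound 2 to compound 4 (0.60 log units; beyond the scatter) and a 3.2-fold lower number from compound 1 to compound 4 (0.51 log units; beyond the scatter), so a group with an aromatic ring and a sulfur link belongs with the best of the four at this position. Nothing available explains why these two groups read alike.

The compounds shown do not separate the sulfur from the aromatic ring; benzyloxy and cyclohexylsulfanyl would pull the two apart. As far as these compounds go, how a group carrying a carboxylic acid or an amine would read at this carbon also stays open.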